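This account rests on a few compounds, and the source may have more. Where it says the series, first, only, none or still open, it means among the compounds named here.

Of the compounds shown here, two have numbers so far in an ADME assay on Vero 76 cells (Chlorocebus sabaeus) for cytotoxicity, read by MTT assay, with a stated time of 96 h; a higher number here means that more compound is tolerated, a lower number that less compound is tolerated (compound 1 `NS(=O)(=O)c1ccc(N2N=C(c3ccccc3)CC2c2ccccc2F)cc1` gives 28000 nM and compound 2 `Cc1cccc(C2CC(c3ccc(Oc4ccccc4)cc3)=NN2c2ccc(S(N)(=O)=O)cc2)c1` gives 81000 nM). Compound 2 therefore holds the higher of the two numbers, and its gap to compound 1 lies beyond the usual scatter. The next compound to be measured, compound 3 (`Cc1cccc(C2CC(c3ccccc3)=NN2c2ccc(S(N)(=O)=O)cc2)c1`), differs from compound 2 in one place: hydrogen in place of phenoxy on an aromatic carbon, para to a large group (hydrogen in place of phenoxy on an aromatic carbon). Among the measured compounds shown here, no step between measured compounds isolates this change, so the expectation rests on thin ground. Compound 1 also carries no phenoxy, although it differs from compound 3 elsewhere too, and its number in this assay is the lower one (compound 1 at 28000 nM). A move to a lower number is therefore expected, of a size only modestly beyond the scatter, and the estimate for it is a drop (a 2.3-fold lower number from compound 2 to compound 3 (0.36 log units; beyond the scatter)). The half-maximal cytotoxic concentration of compound 3 is expected to be about 35000 nM (estimated range 13000 nM to 90000 nM).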

Compound 3, half-maximal cytotoxic concentration: 25000 nM
The estimate for compound 3 lay 1.4-fold (0.15 log units) above the measured number; measured number inside the range.
By their numbers in this assay, from the lowest: compounds 3 and 1 (each within the scatter of the next); then compound 2.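

In this assay, among the compounds shown here, hydrogen in place of phenoxy on the aromatic carbon para to a large group gives a 3.2-fold lower number from compound 2 to compound 3 (0.51 log units; beyond the scatter), the first reading that isolates this change, and it shows that more compound is tolerated with phenoxy at this position than without it. For the compounds shown here, the other step concerns the saturated ring carbon, where 3-methylphenyl in place of 2-fluorophenyl gives a 1.1-fold lower number from compound 1 to compound 3 (0.05 log units; within the scatter), so of the two single changes now in hand, only the one at the aromatic carbon moves the number beyond the scatter. Nothing available here accounts for the size or direction of either step.

From the compounds shown here alone, each change rests on a single pair, so it remains open whether phenoxy would bring the same rise with 2-fluorophenyl on the saturated ring carbon instead of 3-methylphenyl. Going by these compounds, it is also open whether the number depends on the whole phenoxy group, or whether a methoxy group or an amine on that same aromatic carbon would give a number nearer that of compound 2 or that of compound 3.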